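Halogenated benzyl groups on a piperidinol ubiquitin hydrolase inhibitor

The source may report more compounds than this note shows. Statements on the series, on what has been measured and on what is new or still open speak of the compounds shown alone.

Measured compounds:
compound 1, `O=c1c2cnn(-c3ccc(F)cc3)c2ncn1CC1(O)CCN(Cc2ccc(F)cc2)CC1` — "not determined" (no result reported)
compound 2, `O=c1c2cnn(-c3ccc(F)cc3)c2ncn1CC1(O)CCN(Cc2ccccc2Cl)CC1` — 3400 nM
compound 3, `COC(=O)c1ccccc1CN1CCC(O)(Cn2cnc3c(cnn3-c3ccc(F)cc3)c2=O)CC1` — "not determined" (no result reported)

The three measured compounds share one core and differ only in the group on the saturated chain carbon bound to the amine nitrogen in the ring. In an assay on Sf21 cells for inhibition of ubiquitin carboxyl-terminal hydrolase 7 (Homo sapiens), read by spectrophotometry, with stated times of 30 min and 2 h (a higher number here means a weaker inhibitor, a lower number a stronger inhibitor), compound 1 gives "not determined" (no result reported), so compound 1 stands on no number at all; compound 3 likewise gives "not determined" (no result reported). Among the measured compounds shown here, the single anchor is compound 2, which in this assay gives 3400 nM.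

Compound 4, `O=c1c2cnn(-c3ccc(F)cc3)c2ncn1CC1(O)CCN(Cc2ccc(Br)cc2Cl)CC1`, has not yet been measured. It differs from compound 1 as follows: 4-bromo-2-chlorophenyl in place of 4-fluorophenyl on a saturated chain carbon bound to an amine nitrogen in a ring. For the measured compounds named here, no step between measured compounds exists for this change, and compound 1 itself has no value, so the size of the step cannot be computed. Against the only number known, that of compound 2, the expectation is for a result of the same order, with no shift clearly beyond the scatter in either direction, perhaps a slight move toward a lower number.

Compound 4 is therefore expected to give about 2500 nM in this assay, estimated to fall between 600 nM and 10000 nM.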

Compound 4, half-maximal inhibitory concentration: 1900 nM
Compound 4: the middle estimate sits 1.3-fold (0.12 log units) above what was measured, and the stated range covers the measured number.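

In this assay, bromo in place of hydrogen on an aromatic carbon of the benzyl group gives a 1.8-fold lower number from compound 2 to compound 4 (0.25 log units; within the scatter). Among the compounds shown here, this pair is the first reading at this position, on the saturated chain carbon bound to the amine nitrogen in the ring, and it shows that the 4-bromo-2-chlorobenzyl group of compound 4 keeps the result at the level of compound 2, with the added halogen making no difference that can be told from scatter. The steps involving compound 1 and compound 3 cannot be read, since neither compound has a number, and no measurement here explains the result.

The compounds shown therefore leave open how the 4-fluorobenzyl group compares with the 4-bromo-2-chlorobenzyl group, and whether bromo would give a similar reading on a benzyl group without the chlorine. They also leave open how this assay would respond to a carboxylic acid or an amine on the benzyl ring, or to a longer chain between that ring and the amine nitrogen.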